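Changing the group on the ring amine nitrogen

The source may report more compounds than this note shows. Statements on the series, on what has been measured and on what is new or still open speak of the compounds shown alone.

Compound 1 `Cc1cccc2sc(NC(=O)CCN3CCN(CCCN(C)C)CC3)nc12` and compound 2 `Cc1ccccc1N1CCN(CCC(=O)Nc2nc3c(C)cccc3s2)CC1` share a core and differ only in the group on an amine nitrogen in a ring. In an assay on membranes from liver for displacement of a labelled ligand from Sigma intracellular receptor 2 (Rattus norvegicus), read by scintillation counting, with a stated time of 120 min (on this read-out lower numbers stand for stronger inhibition and higher numbers for weaker inhibition), compound 1 gives > 1000 nM, which is a limit of the assay rather than a number. In this assay compound 2 gives > 1000 nM, again a limit. The step that the two limits leave unreadable from compound 1 to compound 2 is thus unreadable in size and direction. Both values sit at the limit of > 1000 nM in this assay, at which 2 of the 2 values shown sit, so compound 2 stands at that limit and nowhere more precisely.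

Compound 3 `Cc1cccc2sc(NC(=O)CCN3CCN(c4ccncc4)CC3)nc12` differs from compound 2 by pyridin-4-yl in place of 2-methylphenyl on an amine nitrogen in a ring. For the measured compounds named here, the only measured step, a step that the two limits leave unreadable from compound 1 to compound 2, concerns the same position, yet it offers no size against which to set the new change. What compound 1 and compound 2 show is that two different groups on that ring nitrogen both leave the read-out at the limit. For compound 3 the expected step that the limit leaves unreadable from compound 2 to compound 3 is accordingly none beyond the scatter. Compound 3 is estimated at 3000 nM, within 500 nM to 20000 nM, and is expected most likely to be reported again only as a limit.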

Compound 3, inhibition constant: 1700 nM
Compound 3: middle estimate off by 1.8-fold (0.25 log units), on the high side; measured number inside the range.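

In this assay compound 3 gives 1700 nM. For the compounds shown here, no step from compound 1 or compound 2 to compound 3 can be read, because compound 1 and compound 2 stand only at a limit: the limit of > 1000 nM in this assay, at which 2 of the 3 values shown sit. The compounds shown leave open how far compound 1 and compound 2 actually lie from compound 3.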